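Pyrrolidine nitrogen substituent change on the shared core

The source may hold more compounds than are shown below. What is called first, only, known or untested is meant among the compounds shown, and "the series" means these compounds.

Measured so far in a functional assay on HCC827 cells (Homo sapiens) for antiproliferative activity, read by MTT assay, with a stated time of 72 h; on this read-out lower numbers stand for stronger inhibition and higher numbers for weaker inhibition:
compound 1 `CN1CCN(c2ccc(Nc3ncc4nc(Nc5ccccc5)n([C@H]5CCN(C(=O)OC(C)(C)C)C5)c4n3)cc2)CC1`: 110 nM
compound 2 `CN1CCN(c2ccc(Nc3ncc4nc(Nc5ccccc5)n([C@@H]5CCN(C(=O)OC(C)(C)C)C5)c4n3)cc2)CC1`: 12 nM

In this assay compound 1 gives 110 nM while compound 2 gives 12 nM; the step is a 9.2-fold lower number from compound 1 to compound 2 (0.96 log units; beyond the scatter), and it rests on (the fact that compounds 1 and 2 differ only in the configuration as drawn). Among the compounds with values here, compound 2 stands at the lowest of the two numbers measured, with compound 1 the only neighbour.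

Compound 3 `CNC(=O)CN1CC[C@H](n2c(Nc3ccccc3)nc3cnc(Nc4ccc(N5CCN(C)CC5)cc4)nc32)C1` is not yet measured. It differs from compound 2 by 1-((methylcarbamoyl)methyl)pyrrolidin-3-yl in place of 1-(tert-butoxycarbonyl)pyrrolidin-3-yl on an aromatic nitrogen. Within the data shown here, no measured step bears on this change: the only step measured, a 9.2-fold lower number from compound 1 to compound 2 (0.96 log units; beyond the scatter), concerns configuration alone and leaves the pyrrolidine nitrogen substituent untouched, so it gives no direction for the present change. Compound 3 is therefore expected to stay close to compound 2 in this assay, with a wide range reflecting the absence of any comparable step. Compound 3 is estimated at 15 nM (range 4 nM to 60 nM). The step this estimate implies is a 1.3-fold higher number from compound 2 to compound 3 (0.10 log units; within the scatter), expected to lie within the scatter.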

Compound 3, half-maximal inhibitory concentration: 170 nM
Compound 3: the middle estimate sits 11-fold (1.05 log units) below what was measured; the whole stated range lies below it.
By their numbers in this assay, from the lowest: compound 2; then compounds 1 and 3 (each within the scatter of the next).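

In this assay, placing (methylcarbamoyl)methyl on the pyrrolidine nitrogen gives a 14-fold higher number from compound 2 to compound 3 (1.15 log units; beyond the scatter), but this step also reverses the drawn stereocentre, so it carries configuration as well as the substituent. With the drawn stereocentre held, the same exchange gives a 1.5-fold higher number from compound 1 to compound 3 (0.19 log units; within the scatter), so on this configuration the data do not separate tert-butoxycarbonyl from (methylcarbamoyl)methyl. The larger step therefore cannot be laid on the substituent alone, and configuration by itself already accounts for a step of similar size: the fact that compounds 1 and 2 differ only in the configuration as drawn

On these data alone, it remains open whether (methylcarbamoyl)methyl on the opposite configuration would stay close to compound 2 at 12 nM. The compounds shown also leave open how a free secondary amine, an acetyl group or a longer chain ending in a carboxylic acid would behave on the pyrrolidine nitrogen.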